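The source may report more compounds than this note shows. Statements on the series, on what has been measured and on what is new or still open speak of the compounds shown alone.

Measured compounds:
Compound 1 `Cc1ccc(-c2cc(/N=C3/NC(=O)CS3)cs2)cc1`: > 50000 nM
Compound 2 `COc1ccc(/C=C2\S/C(=N\c3csc(-c4ccc(Cl)cc4)c3)NC2=O)cc1`: 1300 nM

Of the compounds shown here, two have been measured in a functional assay on HCT-116 cells (Homo sapiens) for cytotoxicity, read by MTT assay, with a stated time of 72 h; on this read-out lower numbers stand for stronger inhibition and higher numbers for weaker inhibition. Compound 1 gives > 50000 nM, and this is a limit of the assay rather than a number (the limit of > 50000 nM in this assay, at which 1 of the 2 values shown sits). Going by the values given here, compound 2 gives 1300 nM in this assay, the only actual number among the two values, so it stands alone as the single point from which an expectation can be drawn.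

Compound 3 `O=C1N/C(=N/c2csc(-c3ccc(Cl)cc3)c2)S/C1=C\c1ccc(Br)cc1` is the compound still to be measured. It differs from compound 2 in one place: bromo in place of methoxy on an aromatic carbon. The methoxy group on the ring that sits para to a large group is replaced by a bromine atom, with the rest of the molecule unchanged.

Among the compounds with values here, no step between measured compounds is available to show what this exchange does in this assay. The expectation is therefore for a step from compound 2 to compound 3 of about a 1.3-fold lower number from compound 2 to compound 3 (0.11 log units; within the scatter), that is, no change beyond the usual scatter of repeated measurements. Compound 3 is estimated to give 1000 nM in this assay, with a range from 400 nM to 2500 nM.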

Compound 3, half-maximal inhibitory concentration: 3300 nM
Compound 3: the middle estimate sits 3.3-fold (0.52 log units) below what was measured; the measured number lies above the stated range.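

In this assay the change from 4-methoxyphenyl to 4-bromophenyl gives a 2.5-fold higher number from compound 2 to compound 3 (0.40 log units; beyond the scatter) and this is the first change in a single place that can be read among these compounds. It shows that the aromatic carbon para to a large group is not indifferent to what it carries: swapping one group for the other moves the number beyond the usual scatter, and methoxy gives the lower number of the two, although the step is only modest. Nothing given here bears on why the exchange has this effect, so the step stands as an observation without an explanation.

As far as these compounds go, a single pair cannot show a trend, so it remains open whether the lower number with methoxy reflects something particular to that group or whether other groups would do as well or better. From the compounds shown here alone, how hydroxy, an amine, a carboxylic acid or a longer chain such as ethoxy would read on this same carbon remains open, as does whether this exchange would give a similar step on a different core.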